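A few compounds are considered here, and "the series" means these few. Any claim that something is new, unique, unknown or untested is made for them only; others in the source may bear on it.

Measured compounds:
- compound 1, `c1ccc(-c2ccc(Cn3cncc3CNc3cccc(-c4ccccc4)c3)cc2)cc1`: 10000 nM
- compound 2, `COC(=O)c1ccc(NCc2cncn2Cc2cccc([N+](=O)[O-])c2)cc1-c1ccccc1`: > 10000 nM
- compound 3, `COC(=O)c1ccc(NCc2cncn2Cc2ccccc2Cl)cc1-c1ccccc1`: 10000 nM

In a toxicity assay on NIH3T3 cells (Mus musculus) for cytotoxicity, read by resazurin assay (a higher number here means that more compound is needed for the effect, a lower number that less compound is needed), compound 3 gives 10000 nM. This stands level with compound 1 at the digits shown, so the two values are within the scatter of each other. For compound 2 only a limit of the assay is reported, not a number: the limit of > 10000 nM in this assay, at which 1 of the 3 values shown sits. Going by the values given here, the one step between measured compounds, a number no higher from compound 2 to compound 3 (the limit leaves the size open), therefore has no readable size.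

Compound 4, `COC(=O)c1ccc(NCc2cncn2Cc2ccc(-c3ccccc3)cc2)cc1-c1ccccc1`, differs from compound 3 in one place: 4-phenylphenyl in place of 2-chlorophenyl on a saturated chain carbon bound to an aromatic nitrogen. The same 4-phenylphenyl group on a saturated chain carbon bound to an aromatic nitrogen is present in compound 1, which gives 10000 nM in this assay. No measured step bears directly on this change, and the only step shown has no readable size. With compound 1 and compound 3 level with each other, the estimate for compound 4 is a step of no change at the digits printed from compound 3 to compound 4 (within the scatter), that is, no change beyond the scatter. Compound 4 is therefore expected to give about 10000 nM, within a range from 5000 nM to 20000 nM.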

Compound 4, half-maximal effective concentration: > 1000 nM
Compound 4 was reported as a limit; the forecaster's own chance of this, stated with the estimate: 45%; the middle value lies beyond the limit too.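

Compound 4 is reported only as a limit of the assay, > 1000 nM, not as a number. Its steps from compound 1, compound 2 and compound 3 cannot be read. The compounds shown leave open whether 4-phenylphenyl in place of 2-chlorophenyl shifts the value in this assay at all.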